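Series notes: trifluoromethyl analogue of compound 3

A few compounds are considered here, and "the series" means these few. Any claim that something is new, unique, unknown or untested is made for them only; others in the source may bear on it.

Measured so far in an assay on HEK293 cells for activation of Kir3.1/Kir3.2 (Homo sapiens), read by thallium flux; on this read-out higher numbers stand for an effect only at larger amounts of compound and lower numbers for an effect already at smaller amounts:
compound 1 `Cc1cc(NC(=O)Cn2nnc(-c3ccccc3)n2)n(-c2ccccc2)n1`: 3020 nM
compound 2 `Cc1cc(NC(=O)Cn2nnc(-c3ccccc3)n2)n(Cc2ccccc2)n1`: 495 nM
compound 3 `Cc1cc(NC(=O)Cn2nnc(-c3cccc(F)c3)n2)n(C2CCCCC2)n1`: 81 nM

Compound 3 stands lowest of the three numbers; compound 2 is nearest and compound 1 furthest, and both gaps are wider than the usual scatter. Going by the values given here, the only measured step that changes a single place, a 6.1-fold lower number from compound 1 to compound 2 (0.79 log units; beyond the scatter), concerns the group on the aromatic nitrogen and says nothing about the aryl on the far end of the molecule.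

Compound 4 `Cc1cc(NC(=O)Cn2nnc(-c3cccc(C(F)(F)F)c3)n2)n(C2CCCCC2)n1` differs from compound 3 by trifluoromethyl in place of fluoro on an aromatic carbon. Among the compounds with values here, no measured pair bears on this change, so the expectation rests on the structural change alone: a small step in this assay, in either direction, probably within the scatter. For compound 4 the expected value is 100 nM, with a range of 30 nM to 330 nM, which means an expected step of a 1.2-fold higher number from compound 3 to compound 4 (0.09 log units; within the scatter).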

Compound 4, half-maximal effective concentration: 183 nM
Estimate against measurement, compound 4: 1.8-fold (0.26 log units) below; the measured number falls inside the stated range.
By their numbers in this assay, from the lowest: compound 3; then compound 4; then compound 2; then compound 1.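

In this assay, going by these compounds alone, the change from 3-fluorophenyl to 3-(trifluoromethyl)phenyl gives the first measured step at this aromatic carbon: a 2.3-fold higher number from compound 3 to compound 4 (0.35 log units; beyond the scatter), modest but beyond the scatter. The number at this position therefore responds to the group placed there, and the larger trifluoromethyl gives the higher number of this pair. No evidence on hand bears on why the number moves. From the compounds shown here alone, whether a nitrile, a methoxy group or plain hydrogen on this carbon would give a lower or higher number remains open. So does whether the step holds with benzyl on the aromatic nitrogen.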